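The source may hold more compounds than are shown below. What is called first, only, known or untested is meant among the compounds shown, and "the series" means these compounds.

Working notes on the series. Compound 1 `O=C(/C=C/c1ccccc1C(F)(F)F)c1cccc(O)c1`, compound 2 `O=C(/C=C/c1ccccc1C(F)(F)F)c1ccc(O)cc1` and compound 3 `O=C(/C=C/c1ccc(C(F)(F)F)cc1)c1cccc(O)c1` share one core; compound 4 `O=C(/C=C/c1ccc(C(F)(F)F)cc1)c1ccc(O)cc1` is not yet measured. In a functional assay on RAW264.7 cells (Mus musculus) for inhibition, read by fluorescence, with stated times of 1 h, 24 h and 30 min (on this read-out lower numbers stand for stronger inhibition and higher numbers for weaker inhibition), compound 1 gives only a limit, > 10000 nM. In this assay compound 2 likewise gives only a limit, > 10000 nM. In this assay compound 3 also gives only a limit, > 10000 nM. The change from compound 1 to compound 2 is 4-hydroxyphenyl in place of 3-hydroxyphenyl on a carbonyl carbon; its step, a step that the two limits leave unreadable from compound 1 to compound 2, cannot be read because the limit of > 10000 nM in this assay, at which 3 of the 3 values shown sit, sits under every value shown. The difference between the core of compound 1 and the core of compound 3 is not broken down here. The change from compound 3 to compound 4 is 4-hydroxyphenyl in place of 3-hydroxyphenyl on a carbonyl carbon, the same change as that from compound 1 to compound 2. For compound 4 the expected step is a step that the limit leaves unreadable from compound 3 to compound 4, which rests on compound 3 showing only > 10000 nM and on (the limit of > 10000 nM in this assay, at which 3 of the 3 values shown sit). Compound 4 is therefore estimated at 20000 nM in this assay, with an expected range from 8000 nM to 60000 nM, most likely reported as a limit.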

Compound 4, half-maximal inhibitory concentration: > 10000 nM
Compound 4: no number, only a limit; the forecaster's own chance of this, stated with the estimate: 85%; the middle value does not contradict the limit.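

In this assay compound 4 gives > 10000 nM as a limit, not a number. No new step can be read between compound 3 and compound 4, since the series sits at one limit: the limit of > 10000 nM in this assay, at which 4 of the 4 values shown sit. The compounds shown leave open how strongly any of them inhibits and whether 4-hydroxyphenyl in place of 3-hydroxyphenyl changes inhibition at all.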